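This account rests on a few compounds, and the source may have more. Where it says the series, first, only, none or still open, it means among the compounds named here.

Measured so far:
- compound 1, `C#CCOc1cccc(-c2cc(-c3cccc(OCC#C)c3)nc(-c3ccccc3)n2)c1`: in an assay on BTI-TN-5B1-4 cells for inhibition of Amine oxidase [flavin-containing] A (Homo sapiens), read by fluorescence and Amplex Red, using microsomes, with a stated time of 30 min (on this read-out lower numbers stand for stronger inhibition and higher numbers for weaker inhibition), compound 1 gives "not active" (no number reported), with no number given
- compound 2, `C#CCOc1ccc(-c2cc(-c3cccc(OCC#C)c3)nc(N)n2)cc1`: in this assay compound 2 gives 24100 nM
- compound 3, `C#CCOc1ccc(-c2cc(-c3cccc(OCC#C)c3)nc(C)n2)cc1`: in this assay compound 3 gives 21100 nM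

Among the compounds with values here, compound 3 has the lowest of the two reported numbers, but the only step is a 1.1-fold lower number from compound 2 to compound 3 (0.06 log units; within the scatter), so the two cannot be told apart. Compound 4, `C#CCOc1ccc(-c2cc(-c3cccc(OCC#C)c3)nc(-c3ccccc3)n2)cc1`, differs from compound 3 by phenyl in place of methyl on an aromatic carbon. Within the data shown here, no measured step matches this exchange; the one step available, from amino to methyl, lay within the scatter. Compound 1, which also carries a phenyl at this place, gave no number. Compound 4 is therefore expected to give 60000 nM, within 20000 nM to 200000 nM, a weakening estimated as a 2.8-fold higher number from compound 3 to compound 4 (0.45 log units; beyond the scatter).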

Compound 4, half-maximal inhibitory concentration: 25800 nM
Compound 4: the middle estimate sits 2.3-fold (0.37 log units) above what was measured; measured number inside the range.
By their numbers in this assay, from the lowest: compounds 3, 2 and 4 (each within the scatter of the next).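

On an aromatic carbon between two ring nitrogen atoms, in this assay, phenyl in place of methyl gives a 1.2-fold higher number from compound 3 to compound 4 (0.09 log units; within the scatter) and phenyl in place of amino gives a 1.1-fold higher number from compound 2 to compound 4 (0.03 log units; within the scatter). Amino, methyl and phenyl therefore cannot be told apart at this place, even though phenyl brings a six-membered aromatic ring of 6 heavy atoms where methyl has 1 heavy atom. No measurement at hand accounts for this result. Still open, going by these compounds, is whether a carboxylic acid or a longer chain at this place would give a number clearly apart from these.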